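From compound 3 to compound 4: trifluoromethyl to 3-cyanopropyl

The compounds below may be only part of what the source reports. "The series", "measured", "known", "first", "only" and "open" are said of these compounds alone.

Compound 1 (`CC(C)n1nc(C(=O)N[C@H]2COc3ccccc3N(C)C2=S)nc1Cc1ccccc1`), compound 2 (`CN1C(=S)[C@@H](NC(=O)c2nc(Cc3ccccc3)n(CCCO)n2)COc2ccccc21`) and compound 3 (`CN1C(=S)[C@@H](NC(=O)c2nc(Cc3ccccc3)n(CCC(F)(F)F)n2)COc2ccccc21`) share one core. In a toxicity assay on HT-29 cells (Homo sapiens) for cytotoxicity (a lower number here means that less compound is tolerated, a higher number that more compound is tolerated), compound 1 gives > 100000 nM as a limit of the assay. Compound 2 gives > 100000 nM as a limit too. Compound 3 stands at > 100000 nM and this is also a limit, not a number. Together the series shows the limit of > 100000 nM in this assay, at which 3 of the 3 values shown sit, and nothing finer.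

Compound 4 (`CN1C(=S)[C@@H](NC(=O)c2nc(Cc3ccccc3)n(CCCCCC#N)n2)COc2ccccc21`) has 3-cyanopropyl in place of trifluoromethyl on a saturated chain carbon, two bonds along the chain from an aromatic nitrogen. For the measured compounds named here, the steps that bear on it are a step that the two limits leave unreadable from compound 2 to compound 3 at this same carbon, then a step that the two limits leave unreadable from compound 1 to compound 2 and a step that the two limits leave unreadable from compound 1 to compound 3 on the aromatic nitrogen. None of them has a readable size, so no step beyond the scatter and no direction is expected in this assay. The expected step is a number no higher from compound 3 to compound 4 (the limit leaves the size open) and another report as a limit is likely. For compound 4 the estimate is 100000 nM with an expected range of 30000 nM to 200000 nM in this read-out.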

Compound 4, half-maximal cytotoxic concentration: > 100000 nM
Compound 4 ended at the assay's limit (the forecaster's own chance of this, stated with the estimate: 85%); the middle value lies on the limit itself.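

In this assay compound 4 gives > 100000 nM, which is a limit, and no step from compound 1, compound 2 or compound 3 to compound 4 can be read: the limit of > 100000 nM in this assay, at which 4 of the 4 values shown sit.

The compounds shown leave open whether any group on the aromatic nitrogen shifts the read-out in this assay, as none of them gives a number.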